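The source may report more compounds than this note shows. Statements on the series, on what has been measured and on what is new or still open speak of the compounds shown alone.

The measured compounds:
compound 1 `C=C(c1ccc(Cl)c(Cl)c1)C1COC2(CCCCC2)OO1` gives 83500 nM in a functional assay on L02 cells (Homo sapiens) for inhibition, read by MTT assay, with a stated time of 72 h; a lower number here means a stronger inhibitor, a higher number a weaker inhibitor
compound 2 `C=C(c1ccc(Cl)c(Cl)c1Cl)C1COC(C)(C)OO1` gives 18100 nM
compound 3 `C=C(c1ccc(Cl)c(Cl)c1Cl)C1COC2(CCCCC2)OO1` gives 1220 nM

Among these three, compound 3 gives the lowest number, compound 2 stands between, and compound 1 gives the highest. Compound 3 and compound 1 differ in one place only, (hydrogen in place of chloro on an aromatic carbon), and that single change carries a 68-fold higher number from compound 3 to compound 1 (1.84 log units; beyond the scatter). Compound 2 and compound 3 carry the same aromatic ring but are built on different cores; the difference between the two cores is not broken down here, and what their two values show is that compound 3 gives the lower number.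

Compound 4 `C=C(c1ccc(Cl)cc1Cl)C1COC(C)(C)OO1` has not yet been measured. It differs from compound 2 by hydrogen in place of chloro on an aromatic carbon. Among the compounds with values here, this is the same kind of change as the one from compound 3 to compound 1, but the place is not the same: in compound 3 the leaving chloro sits ortho to a chloro group, ortho to a large group and meta to a chloro group, whereas in compound 2 it sits ortho to two chloro groups and meta to a large group. The step has been seen only once, on the core of compound 3.

For compound 4 a step of a 6.6-fold higher number from compound 2 to compound 4 (0.82 log units; beyond the scatter) is expected, somewhat smaller than the earlier one because a 68-fold higher number from compound 3 to compound 1 (1.84 log units; beyond the scatter) was seen at a different place on a core that already gives a lower number than compound 2. Compound 4 is estimated at 120000 nM, with a likely range from 30000 nM to 400000 nM; at such numbers the assay may report only a limit.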

Compound 4, half-maximal inhibitory concentration: 37700 nM
Estimate against measurement, compound 4: 3.2-fold (0.50 log units) above; low and high end bracket the measured number.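

In this assay the replacement of a chloro by hydrogen on the aromatic ring brings a 2.1-fold higher number from compound 2 to compound 4 (0.32 log units; beyond the scatter) and so moves the number the same way as on the core of compound 3, but the two steps differ in size by more than the scatter allows: the same change on two cores in this assay, a 68-fold higher number (1.84 log units; beyond the scatter) from compound 3 to compound 1 and a 2.1-fold higher number (0.32 log units; beyond the scatter) from compound 2 to compound 4, 33-fold (1.52 log units) apart, beyond the scatter of two such steps

The direction of the change therefore held in both pairs, whereas its size did not carry over, and a step read on one of these cores gave no reliable measure of the step on the other. What this does not show is whether the gap belongs to the core or to the place on the ring, since the chloro leaves a different place in each pair and each pair was seen only once.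

The compounds shown leave open how large the step would be if the same place lost its chloro on both cores, which would separate these two influences. They also leave open whether the pattern would hold with fluoro or methoxy in place of the chloro, or with a longer chain in place of the two methyl groups on the core of compound 2.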